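The source may report more compounds than this note shows. Statements on the series, on what has been measured and on what is new or still open speak of the compounds shown alone.

Compound 1 `CCCCOCNc1n[n+]([O-])c2ccccc2[n+]1[O-]` gives 14700 nM in a functional assay on PC-3 cells (Homo sapiens) for cytotoxicity, read by MTT assay, with a stated time of 72 h; on this read-out higher numbers stand for weaker inhibition and lower numbers for stronger inhibition.
Compound 2 `CCCOCNc1n[n+]([O-])c2ccccc2[n+]1[O-]` gives 14200 nM.
Compound 3 `CCOCNc1n[n+]([O-])c2ccccc2[n+]1[O-]` gives 15900 nM.

Compound 3 carries the highest number of the three, yet its gaps to both others lie within the scatter, so the three cannot be told apart on these numbers. Compound 4 `CCCCCCCOCNc1n[n+]([O-])c2ccccc2[n+]1[O-]` differs from compound 3 by pentyl in place of hydrogen on a saturated chain carbon, two bonds along the chain from an oxygen on a saturated carbon. The chain at this place has already been varied: a 1.1-fold higher number from compound 2 to compound 3 (0.05 log units; within the scatter) and a 1.1-fold higher number from compound 1 to compound 3 (0.03 log units; within the scatter), both within the scatter. Extending the chain further is therefore expected to change little, and the step of a 1.1-fold lower number from compound 3 to compound 4 (0.06 log units; within the scatter) is estimated to stay within the scatter. Compound 4 is expected to give about 14000 nM in this assay, with a range from 6500 nM to 30000 nM.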

Compound 4, half-maximal inhibitory concentration: 1210 nM
Beside the measured number, compound 4's estimate is 12-fold (1.06 log units) above it; measured number below the stated range.
By their numbers in this assay, from the lowest: compound 4; then compounds 2, 1 and 3 (each within the scatter of the next).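

At this place the chain length does matter in this assay after all: pentyl in place of hydrogen gives a 13-fold lower number from compound 3 to compound 4 (1.12 log units; beyond the scatter) while butyl in place of hydrogen gives a 12-fold lower number from compound 2 to compound 4 (1.07 log units; beyond the scatter) and propyl in place of hydrogen gives a 12-fold lower number from compound 1 to compound 4 (1.08 log units; beyond the scatter) even though the three shorter chains could not be told apart. So the shorter chains gave no hint of this large step. Nothing measured here explains it.

Where the number starts to fall between these lengths remains open. So does whether a longer chain, or a chain carrying an amine, would lower it further.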